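The source may hold more compounds than are shown below. What is called first, only, known or untested is meant among the compounds shown, and "the series" means these compounds.

Of the compounds shown here, three have been measured so far in a functional assay on Jurkat cells (Homo sapiens) for inhibition; on this read-out lower numbers stand for stronger inhibition and higher numbers for weaker inhibition. Compound 1 `CCOC(=O)c1cnc(NN2C(=O)CCC2=O)nc1C(F)(F)F` gives 1600 nM. Compound 2 `CCOC(=O)c1cnc(N(C(=O)NC)N2C(=O)C=C(C)C2=O)nc1C(F)(F)F` gives 590 nM. Compound 3 `CCOC(=O)c1cnc(NN2C(=O)C=C(C)C2=O)nc1CC` gives 400 nM, the lowest of the three numbers; its gap to compound 2 lies within the usual scatter of repeated measurements, so the two cannot be told apart, while its gap to compound 1 lies beyond that scatter. Compound 4 `CCOC(=O)c1cnc(NN2C(=O)C=C(C)C2=O)nc1-c1nccs1` has not yet been measured in this assay. It differs from compound 3 in one place: 1,3-thiazol-2-yl in place of ethyl on an aromatic carbon. Among the measured compounds shown here, no pair of measured compounds shows a change of this kind, so there is nothing among the measured numbers to anchor the size of the step. The step from compound 3 to compound 4 is expected to be small, a 1.1-fold lower number from compound 3 to compound 4 (0.06 log units; within the scatter), with no firm direction. For compound 4 the expected number in this assay is 350 nM, with a range from 80 nM to 1500 nM.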

Compound 4, half-maximal inhibitory concentration: 2200 nM
Compound 4: the middle estimate sits 6.3-fold (0.80 log units) below what was measured, outside the stated range (above it).
By their numbers in this assay, from the lowest: compounds 3 and 2 (each within the scatter of the next); then compounds 1 and 4 (each within the scatter of the next).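

The aromatic carbon next to the ring nitrogen does not treat all groups alike: in this assay, 1,3-thiazol-2-yl in place of ethyl gives a 5.5-fold higher number from compound 3 to compound 4 (0.74 log units; beyond the scatter) and so weakens inhibition. This is the first one-place change among the compounds shown, so it is the first direct sign that the group on this carbon can move the number. No measurement at hand explains why the step occurs.

A single pair cannot tell whether the weaker inhibition belongs to this particular thiazole or to any aromatic ring on this carbon, and a phenyl ring or a thiophene there would help separate the two. A methyl group or a propyl chain in place of ethyl would show how the number follows chain length here.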